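A few compounds are considered here, and "the series" means these few. Any claim that something is new, unique, unknown or untested is made for them only; others in the source may bear on it.

Compound 2 `COc1ccc(-n2cnc3cc(C(=O)N4CCCCC4)ccc32)cc1` gives 19 nM in an assay on isolated protein for inhibition of 15-hydroxyprostaglandin dehydrogenase [NAD(+)] (Homo sapiens), read by fluorescence, with a stated time of 15 min; a higher number here means a weaker inhibitor, a lower number a stronger inhibitor. Its closest measured relative, compound 1 `COc1cccc(-n2cnc3cc(C(=O)N4CCCCC4)ccc32)c1`, gives 19 nM in this assay, so the two stand level: no change at the digits printed from compound 1 to compound 2 (within the scatter). Compound 3 `CCCCn1cnc2cc(C(=O)N3CCCCC3)ccc21` differs from compound 2 by butyl in place of 4-methoxyphenyl on an aromatic nitrogen. Within the data shown here, the single measured step only swaps one methoxyphenyl for another, and nothing measured here shows what removing the ring altogether does, so the step is poorly anchored. The expected change is a 3.2-fold higher number from compound 2 to compound 3 (0.50 log units; beyond the scatter), a loose guess leaning toward slightly weaker inhibition. Compound 3 is therefore estimated at 60 nM, within a range from 10 nM to 400 nM.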

Compound 3, half-maximal inhibitory concentration: 68 nM
For compound 3 the middle estimate is 1.1-fold (0.05 log units) below the measured one; the measured number falls inside the stated range.
By their numbers in this assay, from the lowest: compounds 1 and 2 (each within the scatter of the next); then compound 3.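

Putting butyl in place of a methoxyphenyl gives a 3.6-fold higher number from compound 2 to compound 3 (0.55 log units; beyond the scatter) and a 3.6-fold higher number from compound 1 to compound 3 (0.55 log units; beyond the scatter) in a modest loss. Compound 3 still gives 68 nM in this series, so at this aromatic nitrogen the inhibitor keeps measurable activity without a ring there. The change removes the ring and the oxygen together, so their separate contributions cannot be told apart, and no supporting data explain the step.

Still open, going by these compounds, is how an unsubstituted phenyl ring would compare with these groups. Also open, on these data alone, is whether a shorter chain such as methyl, or a butyl chain ending in an amine, would change the result.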